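This account rests on a few compounds, and the source may have more. Where it says the series, first, only, none or still open, it means among the compounds named here.

Measured in an ADME assay on MT4 cells (Homo sapiens) for cytotoxicity, read by MTT assay, with a stated time of 5 days; a lower number here means that less compound is tolerated, a higher number that more compound is tolerated:
compound 1 `Cc1cc(C#N)cc(C)c1Oc1nc(Nc2ccc(C#N)cc2)ncc1-c1ccoc1`: 4980 nM
compound 2 `Cc1cc(C#N)cc(C)c1Oc1nc(Nc2ccc(C#N)cc2)ncc1-c1ccc(C(F)(F)F)cc1`: 35000 nM

Among the measured compounds shown here, compound 2 has the higher of the two numbers in this assay; the only measured step, a 7.0-fold higher number from compound 1 to compound 2 (0.85 log units; beyond the scatter), shows how far a change of the aryl group on this carbon of the shared core can move the number. Compound 3 `Cc1cc(C#N)cc(C)c1Oc1nc(Nc2ccc(C#N)cc2)ncc1-c1ccc2ccccc2c1` differs from compound 2 by naphthalen-2-yl in place of 4-(trifluoromethyl)phenyl on an aromatic carbon. That step bears on the new change only loosely, as it concerns the same position. A step of similar size, more likely downward, is expected, a 2.3-fold lower number from compound 2 to compound 3 (0.37 log units; beyond the scatter). Compound 3 is estimated at 15000 nM, range 4000 nM to 50000 nM.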

Compound 3, half-maximal cytotoxic concentration: 8460 nM
Compound 3: the middle estimate sits 1.8-fold (0.25 log units) above what was measured, and the stated range covers the measured number.
By their numbers in this assay, from the lowest: compounds 1 and 3 (each within the scatter of the next); then compound 2.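

In this assay, naphthalen-2-yl in place of 4-(trifluoromethyl)phenyl gives a 4.1-fold lower number from compound 2 to compound 3 (0.62 log units; beyond the scatter) with the heavy-atom count unchanged, so an equal count does not keep the number level at this position. Naphthalen-2-yl in place of furan-3-yl gives a 1.7-fold higher number from compound 1 to compound 3 (0.23 log units; within the scatter) and does not separate these two groups, leaving 4-(trifluoromethyl)phenyl alone apart among the three. No supporting data bear on the reason for this difference.

Among the compounds shown here, whether the trifluoromethyl group or the single ring sets compound 2 apart remains open, and plain phenyl would address that. Going by these compounds, how an amine or a carboxylic acid on this carbon would compare also remains open.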